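The source may report more compounds than this note shows. Statements on the series, on what has been measured and on what is new or still open speak of the compounds shown alone.

Compound 1 `COc1cccc2cc(C(=O)O)cnc12` gives 150 mg/kg in a functional assay on the whole organism (strain Sprague-Dawley) for inhibition, with Rattus norvegicus as the target; on this read-out higher numbers stand for an effect only at larger amounts of compound and lower numbers for an effect already at smaller amounts. For compound 2 `COc1cccc2cc(-c3nn[nH]n3)cnc12` the result in this assay is a limit, > 25 mg/kg. For compound 3 `COc1ccc(OC)c2ncc(-c3nn[nH]n3)cc12` the result in this assay is also a limit, > 50 mg/kg. Compound 3 thus stands at a limit with no number of its own, and one further value in the series is a limit as well. Compound 4 `COc1ccc(OC)c2ncc(C(=O)O)cc12` differs from compound 3 by carboxy in place of 2H-tetrazol-5-yl on an aromatic carbon. Among the measured compounds shown here, the same exchange run the other way is a step that the limit leaves unreadable from compound 1 to compound 2, and the only other measured step is a step that the two limits leave unreadable from compound 2 to compound 3; neither has a readable size because the limit of > 25 mg/kg in this assay, at which 1 of the 3 values shown sits, and the limit of > 50 mg/kg in this assay, at which 1 of the 3 values shown sits, cap what can be read. A step within the scatter is expected, a step that the limit leaves unreadable from compound 3 to compound 4. For the measured compounds named here, compound 1 with its carboxy group gives 150 mg/kg, the only number available. Compound 4 is therefore estimated at 150 mg/kg, between 50 mg/kg and 400 mg/kg.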

Compound 4, minimum effective dose: > 50 mg/kg
Compound 4: a limit, no number; the forecaster's own chance of this, stated with the estimate: 40%; the middle value is on the limit's open side.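

The steps from compound 3 and from compound 1 to compound 4 cannot be read, because compound 4 stands at a limit: the limit of > 50 mg/kg in this assay, at which 2 of the 4 values shown sit.

The compounds shown leave open how carboxy and 2H-tetrazol-5-yl compare, with or without the added methoxy.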